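Vinyl in place of chloropropyl on a tert-butylanilide

A few compounds are considered here, and "the series" means these few. Any claim that something is new, unique, unknown or untested is made for them only; others in the source may bear on it.

Compound 3 `CC(C)(C)c1ccc(NC(=O)CCCCl)cc1` is the starting point of this step, and its reading in a functional assay on HT-29 cells (Homo sapiens) for antiproliferative activity, with a stated time of 48 h (on this read-out lower numbers stand for stronger inhibition and higher numbers for weaker inhibition), tells little on its own. In this assay compound 3 gives > 100000 nM, which is a limit of the assay and not a number. Two measured neighbours frame it. Compound 1 `CC(C)(C)c1ccc(NC(=O)CCCl)cc1` gives 88000 nM in this assay. The step of an at least 1.1-fold higher number from compound 1 to compound 3 (0.05 log units; that floor lies within the scatter) is therefore only a floor. Compound 2 `O=C(CCCCl)Nc1ccc(I)cc1` gives > 100000 nM in this assay, again a limit of the assay. The step that the two limits leave unreadable from compound 2 to compound 3 cannot be sized, because the limit of > 100000 nM in this assay, at which 2 of the 3 values shown sit, holds both ends of it.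

Compound 4 `C=CC(=O)Nc1ccc(C(C)(C)C)cc1` differs from compound 3 by vinyl in place of 3-chloropropyl on a carbonyl carbon. Among the measured compounds shown here, neither measured step touches this kind of change: one alters the aromatic substituent and the other lengthens the chain by a chloromethyl, so the direction of the present step rests on no direct precedent. For the measured compounds named here, the one number in the set, that of compound 1 at 88000 nM, shows that shorter acyl chains on this core can at least reach a measurable value. On that thin basis compound 4 is expected to give 50000 nM, between 8000 nM and 200000 nM. This estimate means a step of an at least 2.0-fold lower number from compound 3 to compound 4 (0.30 log units; that floor lies within the scatter), though a limit remains a real possibility.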

Compound 4, half-maximal inhibitory concentration: 24000 nM
Compound 4: middle estimate off by 2.1-fold (0.32 log units), on the high side; the range from low to high includes it.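

In this assay the change on the carbonyl carbon produces an at least 4.1-fold lower number from compound 3 to compound 4 (0.61 log units; beyond the scatter), and this is a step beyond the scatter, which neither earlier step could offer, since one had only a floor within the scatter and the other could not be read. Compound 3 stands at a limit of the assay and not at a number, so this step is a floor only: the limit of > 100000 nM in this assay, at which 2 of the 4 values shown sit.

With 2-chloroethyl as the group that leaves, both ends are real numbers and the replacement by vinyl gives a 3.7-fold lower number from compound 1 to compound 4 (0.56 log units; beyond the scatter), which shows that the group on this carbonyl carbon can move the read-out on the shared core by a measurable amount.

The compounds shown do not separate the double bond of vinyl from the loss of the chlorine, a question that an ethyl group on the same carbonyl carbon would address directly. They also leave open whether vinyl gives a similar step with iodo in place of tert-butyl on the aromatic carbon, or how a longer unsaturated chain or an amine at the end of the chain would read.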